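The source may hold more compounds than are shown below. What is called first, only, known or untested is meant among the compounds shown, and "the series" means these compounds.

Three compounds share one core and carry a thiazolidinedione group, and they have been compared in a functional assay on MCF7 cells (Homo sapiens), tested at 5 uM; a higher number here means a weaker effect of the compound at the concentration tested, a lower number a stronger effect. Compound 1 `CC(C)=CCOc1c(C)c(C)c2c(c1C)CCC(C)(COc1ccc(/C=C3\SC(=O)NC3=O)cc1C)O2` gives 56% in this assay, the lowest of the three readings and so the strongest effect of the set. Compound 2 `C=CCOc1c(C)c(C)c2c(c1C)CCC(C)(COc1ccc(/C=C3\SC(=O)NC3=O)cc1OCC)O2` gives 87%, and compound 3 `Cc1c(C)c2c(c(C)c1OC(=O)CCC(=O)O)CCC(C)(COc1ccc(/C=C3\SC(=O)NC3=O)cc1)O2` gives 98%; both of these lie beyond the usual scatter from compound 1.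

Compound 4 `CC(C)=CCOc1c(C)c(C)c2c(c1C)CCC(C)(COc1ccc(/C=C3\SC(=O)NC3=O)cc1)O2` has not yet been tested in this assay. It differs from compound 1 in a single place: hydrogen in place of methyl on an aromatic carbon. The change is small, and the step expected from compound 1 to compound 4 is a number 7 percentage points higher from compound 1 to compound 4 (within the scatter), likely within the scatter, perhaps a slight loss of effect. Compound 4 is therefore expected to give about 63%, within 45% to 82%.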

Compound 4, a percentage reported as activity, at one concentration (the size of the read-out at that concentration, not a potency): 21%
Compound 4: middle estimate off by 42 percentage points, on the high side; the whole stated range lies above it.
By their numbers in this assay, from the lowest: compound 4; then compound 1; then compound 2; then compound 3.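

In this assay, a single methyl on this aromatic carbon, ortho to a large group, counts for much: hydrogen in its place gives a number 35 percentage points lower from compound 1 to compound 4 (beyond the scatter). With hydrogen kept at that carbon, the group on the other ring's oxygen also counts, as 3-methylbut-2-en-1-yl in place of (2-carboxyethyl)carbonyl gives a number 77 percentage points lower from compound 3 to compound 4 (beyond the scatter). Nothing available explains why either change has so large an effect.

The compounds shown leave open how a fluorine atom, a chlorine atom or a methoxy group at this carbon would compare with hydrogen and methyl.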